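The source may hold more compounds than are shown below. What is called first, only, known or untested is meant among the compounds shown, and "the series" means these compounds.

Working notes on the series. Compound 1 `O=C(O)/C(=C/c1c[nH]c2ccc(OCc3ccccc3)cc12)c1ccccc1` carries a hydrogen on the aromatic nitrogen and a plain phenyl on the double-bonded chain carbon bound to the carbonyl carbon. In a functional assay on KB cells (Homo sapiens) for cytotoxicity, read by MTT assay, with a stated time of 72 h (on this read-out lower numbers stand for stronger inhibition and higher numbers for weaker inhibition), compound 1 gives 55500 nM. Compound 2 `CC(=O)n1cc(/C=C(/C(=O)O)c2ccccc2)c2cc(OCc3ccccc3)ccc21` gives 55500 nM. The acetyl step is no change at the digits printed from compound 1 to compound 2 (within the scatter). Compound 3 `COc1ccc(/C(=C\c2cn(C(C)=O)c3ccc(OCc4ccccc4)cc23)C(=O)O)cc1OC` gives 96700 nM, and the step to it is a 1.7-fold higher number from compound 2 to compound 3 (0.24 log units; within the scatter). Compound 1 thus stands level with compound 2, the two together at the lowest numbers of the three, and the gap to compound 3 stays within the scatter, so none of the three can be called most or least potent.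

Compound 4 `COc1ccc(/C(=C\c2c[nH]c3ccc(OCc4ccccc4)cc23)C(=O)O)cc1` is not yet measured. Its change from compound 1 is methoxy in place of hydrogen on an aromatic carbon. Within the data shown here, the one measured step that bears on this is a 1.7-fold higher number from compound 2 to compound 3 (0.24 log units; within the scatter), where the phenyl on the same chain carbon was replaced by 3,4-dimethoxyphenyl and the number stayed within the scatter; the change to compound 4, read one bond further out, is phenyl to 4-methoxyphenyl, a lesser version of that. Compound 4 is therefore expected to show a step of a 1.2-fold higher number from compound 1 to compound 4 (0.07 log units; within the scatter), nothing beyond the scatter in either direction. Compound 4 is estimated at 65000 nM, within 30000 nM to 140000 nM.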

Compound 4, half-maximal inhibitory concentration: 38500 nM
Beside the measured number, compound 4's estimate is 1.7-fold (0.23 log units) above it; measured number inside the range.
By their numbers in this assay, from the lowest: compounds 4, 1, 2 and 3 (each within the scatter of the next, the first and the last beyond it).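

In this assay, methoxy on an aromatic carbon of the six-membered ring, para to a large group, gives a 1.4-fold lower number from compound 1 to compound 4 (0.16 log units; within the scatter), so this position takes the group on a core that keeps its hydrogen on the aromatic nitrogen without leaving the scatter. The earlier compounds shown here showed a change on this ring only as 3,4-dimethoxyphenyl with acetyl on the aromatic nitrogen, in a 1.7-fold higher number from compound 2 to compound 3 (0.24 log units; within the scatter); the present step isolates one methoxy on the unacylated core, and across these two steps neither change on the ring goes beyond the scatter. No measurement here bears on why this step has the size it has.

The compounds shown carry only hydrogen or methoxy on this ring, so it remains open whether an amine, a hydroxyl, a chlorine or a longer chain such as butoxy at the same place would leave the scatter. The single methoxy is also not shown with acetyl on the aromatic nitrogen, which leaves open how that pair of changes would read together.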